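The source may report more compounds than this note shows. Statements on the series, on what has been measured and on what is new or still open speak of the compounds shown alone.

Working notes on the series. Three compounds carry numbers in an ADME assay for permeability; on this read-out lower numbers stand for lower permeability and higher numbers for higher permeability. Compound 1 `CNC(=O)c1cc(C(=O)N[C@H]2CC[C@H](O)CC2)n([C@@H](C)c2cccc(Cl)c2)n1` gives 235 nm/s in this assay. Compound 3 `CC[C@@H](c1ccccc1)n1nc(C(=O)NC)cc1C(=O)N[C@H]1[C@@H]2C[C@H](O)C[C@@H]21` gives 230 nm/s, and these two numbers sit within the usual scatter of each other. Compound 2 `CNC(=O)c1cc(C(=O)N[C@H]2CC[C@H](O)CC2)c([C@@H](C)c2cccc(C)c2)o1` gives 85 nm/s, the lowest of the three numbers; its gaps to compound 3 and to compound 1 both lie beyond the scatter, compound 3 being the nearer of the two and compound 1 the further.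

Compound 4 `CNC(=O)c1cc(C(=O)N[C@H]2CC[C@H](O)CC2)c([C@@H](C)c2cccc(F)c2)o1` has not yet been measured in this assay. It differs from compound 2 in one place: fluoro in place of methyl on an aromatic carbon, that is 3-methylphenyl to 3-fluorophenyl, on an aromatic carbon of a six-membered aromatic ring of carbon only, meta to a large group. Among the measured compounds shown here, no pair of measured compounds carries this same change, so nothing measured here sets its size or direction.

The expected step from compound 2 to compound 4 is a 1.1-fold lower number from compound 2 to compound 4 (0.05 log units; within the scatter), a step that is not expected to exceed the usual scatter. The anchor for that expectation is compound 2 at 85 nm/s. Compound 4 is therefore estimated at 75 nm/s, with a range from 40 nm/s to 150 nm/s.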

Compound 4, apparent permeability: 73 nm/s
Compound 4: middle estimate off by 1.0-fold (0.01 log units), on the high side; low and high end bracket the measured number.
By their numbers in this assay, from the lowest: compounds 4 and 2 (each within the scatter of the next); then compounds 3 and 1 (each within the scatter of the next).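

Fluoro in place of methyl on an aromatic carbon, meta to a large group, now has a measured size in this assay: a 1.2-fold lower number from compound 2 to compound 4 (0.07 log units; within the scatter). On this read-out, compound 2 and compound 4 cannot be told apart, so this position takes the change from 3-methylphenyl to 3-fluorophenyl without a step beyond the scatter. Nothing at hand gives a reason for this result.

From the compounds shown here alone, the change rests on this single pair, so whether it would read the same on the core of compound 1 or the core of compound 3 remains open. Also open, going by these compounds, is whether a different group on the same aromatic carbon, such as an amine, a carboxylic acid or a nitrile, would give a step beyond the scatter.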